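This account rests on a few compounds, and the source may have more. Where it says the series, first, only, none or still open, it means among the compounds named here.

Series notes. Compound 1 `COc1ccccc1Nc1nc(-c2cccc(F)c2)nc2ccc(F)cc12` carries the shared core with a 2-methoxyphenyl on the aromatic nitrogen; compound 2 `Fc1cccc(-c2nc(Nc3cccc(Cl)c3)c3cc(F)ccc3n2)c1` and compound 3 `Fc1cccc(-c2nc(Nc3ccccc3Br)c3cc(F)ccc3n2)c1` vary that group. In a functional assay on HL-60 cells (Homo sapiens) for cytotoxicity, read by MTT assay, with a stated time of 48 h (on this read-out lower numbers stand for stronger inhibition and higher numbers for weaker inhibition), compound 1 gives only a limit of the assay, > 50000 nM. In this assay compound 2 likewise gives a limit, > 50000 nM. In this assay compound 3 also gives a limit, > 50000 nM. The measured steps read a step that the two limits leave unreadable from compound 1 to compound 2, a step that the two limits leave unreadable from compound 1 to compound 3 and a step that the two limits leave unreadable from compound 2 to compound 3, since (the limit of > 50000 nM in this assay, at which 3 of the 3 values shown sit). Compound 4 `Cc1ccccc1Nc1nc(-c2cccc(F)c2)nc2ccc(F)cc12` differs from compound 3 by methyl in place of bromo on an aromatic carbon. Going by the values given here, no measured step of readable size bears on this change, and the three reference values all sit at the same limit, so no step beyond the scatter is expected: the expected step is a number no higher from compound 3 to compound 4 (the limit leaves the size open). Compound 4 is therefore expected to give about 50000 nM in this assay, between 20000 nM and 150000 nM, most likely again only a limit.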

Compound 4, half-maximal inhibitory concentration: > 50000 nM
Compound 4: a limit, no number (the forecaster's own chance of this, stated with the estimate: 85%); the middle value lies on the limit itself.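

Compound 4 adds no readable step to compound 1, compound 2 or compound 3 in this assay, because all four give only a limit: the limit of > 50000 nM in this assay, at which 4 of the 4 values shown sit.

On these data alone, whether any of these groups on the aromatic nitrogen changes the read-out stays open.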